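The source may report more compounds than this note shows. Statements on the series, on what has been measured and on what is new or still open speak of the compounds shown alone.

Among the compounds with values here, in a functional assay on HL-60 cells (Homo sapiens) for cytotoxicity, read by WST assay, with a stated time of 48 h (on this read-out lower numbers stand for stronger inhibition and higher numbers for weaker inhibition), only two compounds have numbers so far. Compound 1 `COC[C@H](C)[C@H](C)C(c1ccc(O)c(OC)c1)c1ccc(O)c(OC)c1` gives 82000 nM on this read-out, and compound 2 `COC[C@@H](C)[C@H](C)C(c1ccc(O)c(OC)c1)c1ccc(O)c(OC)c1` gives 73000 nM in the same test, so compound 2 stands level with compound 1 within the usual scatter. Within the data shown here, what separates them is the fact that compounds 1 and 2 differ only in the configuration as drawn, and the only measured step is a 1.1-fold lower number from compound 1 to compound 2 (0.05 log units; within the scatter).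

Compound 3 `COc1cc(C(c2ccc(O)c(OC)c2)[C@@H](CF)C(C)C)ccc1O` replaces the side chain itself, as counted here: 1-(fluoromethyl)-2-methylpropyl in place of 2-(methoxymethyl)-1-methylpropyl on a saturated chain carbon bound to two aromatic carbons. A 1-(fluoromethyl)-2-methylpropyl group thus takes the place of the 2-(methoxymethyl)-1-methylpropyl group on a saturated chain carbon bound to two aromatic carbons.

The step from compound 1 to compound 2 bears on this only weakly, since it changed the drawn configuration and no atoms. Among the measured compounds shown here, no measured step shows what swapping the chain does, so compound 2 at 73000 nM remains the best starting point. No shift beyond the scatter is therefore expected in this assay, and neither direction is favoured. The expected step is a 1.2-fold lower number from compound 2 to compound 3 (0.09 log units; within the scatter), with real uncertainty around it. For compound 3 the estimated value is 60000 nM, within an estimated range of 18000 nM to 150000 nM.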

Compound 3, half-maximal inhibitory concentration: 39000 nM
Estimate against measurement, compound 3: 1.5-fold (0.19 log units) above; low and high end bracket the measured number.
By their numbers in this assay, from the lowest: compounds 3, 2 and 1 (each within the scatter of the next, the first and the last beyond it).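

In this assay, within the data shown here, compound 3 gives the first measured change to the side chain itself, rather than to its drawn configuration, on a saturated chain carbon bound to two aromatic carbons. Placing 1-(fluoromethyl)-2-methylpropyl where 2-(methoxymethyl)-1-methylpropyl stood gives a 1.9-fold lower number from compound 2 to compound 3 (0.27 log units; within the scatter) and a 2.1-fold lower number from compound 1 to compound 3 (0.32 log units; beyond the scatter), so the number does not rise in either case, and this position accepts a chain without the ether oxygen and with a fluorine, at least in these compounds. The two steps are two readings of one exchange of groups, and only the second lies beyond the scatter, by a modest margin, with the starting compounds matching in atoms and bonds: the fact that compounds 1 and 2 differ only in the configuration as drawn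

The compounds shown leave open which part of the exchange matters, as the loss of the methoxymethyl ether, the arrival of the fluorine and the altered branching all come together in compound 3. They also leave open how this position would read with an amine, a carboxylic acid or a longer chain in place of these branched groups.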